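The source may hold more compounds than are shown below. What is called first, only, known or untested is meant among the compounds shown, and "the series" means these compounds.

Compound 3 `O=C1C[C@H](OCc2cc(/C=C/c3ccccc3)no2)[C@H]2CO[C@@H]1O2` is one of three compounds sharing the same core, the others being compound 1 `O=C1C[C@H](OCc2cn(-c3ccc(Cl)cc3)nn2)[C@H]2CO[C@@H]1O2` and compound 2 `O=C1C[C@H](OCc2cn(C3CCCCC3)nn2)[C@H]2CO[C@@H]1O2`. In a functional assay on HT-29 cells (Homo sapiens) for cytotoxicity, read by MTT assay, with a stated time of 48 h (on this read-out higher numbers stand for weaker inhibition and lower numbers for stronger inhibition), compound 1 gives 14700 nM, compound 2 gives 11900 nM and compound 3 gives 13700 nM. Within the data shown here, the only single-point step among them is a 1.2-fold lower number from compound 1 to compound 2 (0.09 log units; within the scatter), and the number for compound 3 sits within the scatter of both neighbours, so the three are indistinguishable on this read-out. Compound 4 `O=C1C[C@H](OCc2cc(-c3ccc(Cl)o3)no2)[C@H]2CO[C@@H]1O2` differs from compound 3 by 5-chlorofuran-2-yl in place of 2-phenylethenyl on an aromatic carbon. Among the measured compounds shown here, no measured step touches this ring position; the one step seen, from compound 1 to compound 2, lies on a different ring and stayed within the scatter, while all three numbers cluster closely. On that basis the step of a 1.1-fold lower number from compound 3 to compound 4 (0.02 log units; within the scatter) is expected to be nothing beyond the scatter. Compound 4 is therefore estimated at 13000 nM in this assay, with a plausible range from 5000 nM to 35000 nM.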

Compound 4, half-maximal inhibitory concentration: 10100 nM
Beside the measured number, compound 4's estimate is 1.3-fold (0.11 log units) above it; measured number inside the range.
By their numbers in this assay, from the lowest: compounds 4, 2, 3 and 1 (each within the scatter of the next).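

In this assay, among these compounds, the exchange of 2-phenylethenyl for 5-chlorofuran-2-yl gives a 1.4-fold lower number from compound 3 to compound 4 (0.13 log units; within the scatter) and so provides the first measured change at this aromatic carbon, the one next to the ring nitrogen of the five-membered aromatic ring with 1 nitrogen and 1 oxygen. Here a six-membered aromatic ring of carbon only, with its double bond outside the ring, gives way to a five-membered aromatic ring carrying oxygen and chlorine, and the number stays within the scatter. Nothing available explains this outcome.

The compounds shown leave open whether an amine or a carboxylic acid at this aromatic carbon would take the number beyond the scatter. They also leave open whether a longer chain there would do so.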